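Furan isomer swap in a dihydropyrimidinone series against A2b

This account rests on a few compounds, and the source may have more. Where it says the series, first, only, none or still open, it means among the compounds named here.

Compound 1 `CC1=C(C(=O)OCC(C)C)C(c2ccco2)NC(=O)N1C` and compound 2 `CC1=C(C(=O)OCC(C)C)C(c2ccoc2)NC(=O)N1C` share one core and differ only in furan-3-yl in place of furan-2-yl on a saturated ring carbon. In an assay on membranes from HEK293 cells for displacement of a labelled ligand from adenosine receptor A2b (Homo sapiens), read by scintillation counting, with a stated time of 30 min, tested at 1 uM (a higher number here means more inhibition at the concentration tested (going by the name of the read-out), a lower number less inhibition), compound 1 gives 4% and compound 2 gives 1%; the step of a number 3 percentage points lower from compound 1 to compound 2 (within the scatter). Compound 3 `CCSC(=O)C1=C(C)NC(=O)NC1c1ccco1` carries a different core, and the difference between the two cores is not broken down here; in this assay compound 3 gives 29%. Compound 4 `CCSC(=O)C1=C(C)NC(=O)NC1c1ccoc1` is not yet measured and differs from compound 3 by furan-3-yl in place of furan-2-yl on a saturated ring carbon. This is the same kind of change as that from compound 1 to compound 2, though the place now sits next to the ring atom that bears a (ethylsulfanyl)carbonyl group rather than an isobutoxycarbonyl group. Because a number 3 percentage points lower from compound 1 to compound 2 (within the scatter), the step of a number 5 percentage points lower from compound 3 to compound 4 (within the scatter) is expected to be small. Compound 4 is thus estimated at 24%, between 8% and 40%.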

Compound 4, a percentage reported as inhibition, at one concentration (the size of the read-out at that concentration, not a potency): 1%
Compound 4: the middle estimate sits 23 percentage points above what was measured, outside the stated range (below it).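

In this assay, the change from furan-2-yl to furan-3-yl does not carry over in size between the two cores: the same change on two cores in this assay, a number 3 percentage points lower (within the scatter) from compound 1 to compound 2 and a number 28 percentage points lower (beyond the scatter) from compound 3 to compound 4, 25 percentage points apart, beyond the scatter of two such steps On the core of compound 3 the change gives a number 28 percentage points lower from compound 3 to compound 4 (beyond the scatter), so the furan isomer matters on that core in this assay. This rests on just two pairs at a single concentration, and it does not show which of the differences between the cores sets the size of the step, or whether the result extends to any other core.

The compounds shown leave open how a phenyl or thiophene ring would read in place of the furan on either core. They also leave open what a longer chain on the sulfur of compound 3 would do.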